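This account rests on a few compounds, and the source may have more. Where it says the series, first, only, none or still open, it means among the compounds named here.

Measured in a functional assay on MCF7 cells (Homo sapiens) for antiproliferative activity, read by sulforhodamine B assay, with a stated time of 48 h; a higher number here means a weaker inhibitor, a lower number a stronger inhibitor:
Compound 1 `CN1CCN(c2ccc(S(=O)(=O)Oc3cccc(Cl)c3)cc2)C1=O` gives 2200 nM
Compound 2 `CCN1CCN(c2ccc(S(=O)(=O)Oc3ccccc3OC)cc2)C1=O` gives > 100000 nM (a limit)
Compound 3 `CCN1CCN(c2ccc(S(=O)(=O)Oc3cccc(F)c3)cc2)C1=O` gives > 100000 nM (a limit)

Compound 3 has no number in this assay, only a limit. It sits at the limit of > 100000 nM in this assay, at which 2 of the 3 values shown sit. Among the measured compounds shown here, the one measured step that reaches compound 3 is a step that the two limits leave unreadable from compound 2 to compound 3, so it offers no size to carry forward.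

Compound 4 `CCN1CCN(c2ccc(S(=O)(=O)Oc3cccc(Cl)c3)cc2)C1=O` keeps the ethyl group of compound 3 and changes in one place only: chloro in place of fluoro on an aromatic carbon. In words, chloro takes the place of fluoro on an aromatic carbon, turning 3-fluorophenyl into 3-chlorophenyl.

For the measured compounds named here, no measured step covers this exchange directly. The nearest guide is compound 1, which carries the same 3-chlorophenyl group but has methyl where compound 4 has ethyl, and compound 1 gives 2200 nM. Resting on compound 1 at 2200 nM, a shift towards stronger inhibition is expected, although the unmeasured difference between methyl and ethyl leaves its size uncertain. A second limit remains possible. The expected change is an at least 16-fold lower number from compound 3 to compound 4 (1.22 log units; beyond the scatter). Compound 4 is estimated at 6000 nM, with an expected range from 1200 nM to 60000 nM.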

Compound 4, half-maximal inhibitory concentration: 5400 nM
Estimate against measurement, compound 4: 1.1-fold (0.05 log units) above, and the stated range covers the measured number.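

In this assay, chloro in place of fluoro on an aromatic carbon, an exchange of one heavy atom for one heavy atom with no ring and no charge involved, brings an at least 18-fold lower number from compound 3 to compound 4 (1.26 log units; beyond the scatter), and replacing the 2-methoxyphenyl group brings an at least 18-fold lower number from compound 2 to compound 4 (1.26 log units; beyond the scatter), so with the ethyl group kept, the choice of group on the sulfonate oxygen decides whether a number can be read at all. Among the compounds shown here, the chain offers the first readable comparison at this place: going from methyl to ethyl with 3-chlorophenyl held constant gives a 2.5-fold higher number from compound 1 to compound 4 (0.39 log units; beyond the scatter), a modest step that still leaves a measurable number with either chain. Compounds 2 and 3 remain limits rather than numbers, so the step between them cannot be read: the limit of > 100000 nM in this assay, at which 2 of the 4 values shown sit.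

Going by these compounds, what a bromo, methoxy or nitrile group would give on the same aromatic carbon remains open, so it cannot be said whether chloro is unusual among such groups or simply differs from fluoro. Equally open, on these data alone, is whether a propyl or longer chain in place of ethyl would extend the modest step seen with the 3-chlorophenyl compounds.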